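A few compounds are considered here, and "the series" means these few. Any claim that something is new, unique, unknown or untested is made for them only; others in the source may bear on it.

Measured in an assay on a protein complex for positive allosteric modulation of Neuronal acetylcholine receptor; alpha4/beta2 (Homo sapiens); on this read-out higher numbers stand for larger maximal responses and lower numbers for smaller maximal responses:
compound 1, `Fc1ccc(-c2cc(-c3cnn(C4CCNCC4)c3)on2)c(Cl)c1`: 56%
compound 2, `Fc1cccc(-c2cc(-c3cnn(C4CCNCC4)c3)on2)c1Cl`: 47%
compound 3, `Clc1cnccc1-c1cc(-c2cnn(C3CCNCC3)c2)on1`: 50%

Compound 3 sits second highest of the three numbers in this assay. Its nearest neighbour is compound 2, with a number 3 percentage points higher from compound 2 to compound 3 (within the scatter); the furthest is compound 1, with a number 6 percentage points lower from compound 1 to compound 3 (within the scatter). The remaining measured step, a number 9 percentage points lower from compound 1 to compound 2 (within the scatter), is likewise within the scatter, so the three compounds cannot be ordered against each other on this read-out.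

Compound 4 is `Cc1cc(-c2cnn(C3CCNCC3)c2)on1`. Relative to compound 3 the difference is methyl in place of 3-chloropyridin-4-yl on an aromatic carbon.

All three measured steps concern the same position on the shared core, and all three exchange one chloro-bearing ring for another; none of them removes the ring altogether or puts a single-carbon group in its place. For the measured compounds named here, they therefore say only that swapping one such ring for another leaves the maximal response roughly unchanged in this assay. Going by the values given here, the change to compound 4 goes beyond what those steps cover, and no measured pair shows its direction. The working expectation is a step downward, a number 15 percentage points lower from compound 3 to compound 4 (beyond the scatter), with wide uncertainty. Compound 4 is estimated at 35% in this assay, with a range from 15% to 58%.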

Compound 4, largest response reached (reported as efficacy), in percent of the reference or control that the assay uses: 19%
Compound 4: middle estimate off by 16 percentage points, on the high side; low and high end bracket the measured number.
By their numbers in this assay, from the lowest: compound 4; then compounds 2, 3 and 1 (each within the scatter of the next).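

In this assay, exchanging the ring at this position for methyl gives a number 31 percentage points lower from compound 3 to compound 4 (beyond the scatter), a number 28 percentage points lower from compound 2 to compound 4 (beyond the scatter) and a number 37 percentage points lower from compound 1 to compound 4 (beyond the scatter), so the same drop appears from all three ring-bearing compounds. The position, an aromatic carbon next to the ring nitrogen, is therefore not indifferent to its substituent: the exchanges among 3-chloropyridin-4-yl and the two chlorofluorophenyl groups stayed within the scatter, whereas replacing any of these rings with a single carbon does not. Nothing on hand explains why the maximal response falls with this change.

The compounds shown go directly from a chloro-bearing six-membered aromatic ring to methyl, so they leave open whether the response depends on the ring itself, on its chlorine, or simply on the number of atoms at this position. Unsubstituted phenyl, cyclohexyl, a longer chain such as n-butyl and an amine such as dimethylamino on the same carbon would separate these possibilities, since each keeps only part of what methyl lacks.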